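Chloro for Methoxy on the Benzoic Acid Ring

This account rests on a few compounds, and the source may have more. Where it says the series, first, only, none or still open, it means among the compounds named here.

Measured so far:
compound 1 `COc1cc(C(=O)O)ccc1OCCCCOc1ccc(C(=O)C(C)C)c(O)c1C` — 113 nM
compound 2 `COc1cc(C(=O)O)ccc1OCCCCOc1ccc(C(=O)CC(C)C)c(O)c1C` — 40 nM

Compound 2 `COc1cc(C(=O)O)ccc1OCCCCOc1ccc(C(=O)CC(C)C)c(O)c1C` carries an isobutyl group on the carbonyl carbon where compound 1 `COc1cc(C(=O)O)ccc1OCCCCOc1ccc(C(=O)C(C)C)c(O)c1C` carries isopropyl. In an assay on HEK293 cells for positive allosteric modulation of metabotropic glutamate receptor 2 (Rattus norvegicus), read by thallium flux, with a stated time of 2.5 min (a higher number here means that more compound is needed for the effect, a lower number that less compound is needed), compound 1 gives 113 nM, and in this assay compound 2 gives 40 nM. This single change gave a 2.8-fold lower number from compound 1 to compound 2 (0.45 log units; beyond the scatter), so compound 2 stands at the lower of the two numbers recorded, its nearest neighbour being compound 1.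

Compound 3 `Cc1c(OCCCCOc2ccc(C(=O)O)cc2Cl)ccc(C(=O)CC(C)C)c1O` keeps the isobutyl ketone of compound 2 and alters the other end of the molecule instead: chloro in place of methoxy on an aromatic carbon. Within the data shown here, no measured step touches this part of the shared core; the one step in hand, from compound 1 to compound 2, concerns the ketone side chain alone. There is therefore nothing in the data that predicts a shift in this assay, and the expectation for compound 3 is a number close to that of compound 2, with any difference likely within the scatter: an estimated step of a 1.3-fold higher number from compound 2 to compound 3 (0.10 log units; within the scatter). Compound 3 is thus expected to give about 50 nM in this assay, within a range of 18 nM to 140 nM.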

Compound 3, half-maximal effective concentration: 96 nM
Compound 3: the middle estimate sits 1.9-fold (0.28 log units) below what was measured; the range from low to high includes it.
By their numbers in this assay, from the lowest: compound 2; then compounds 3 and 1 (each within the scatter of the next).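

Among these compounds, the earlier compounds differ only in the ketone side chain, so this is the first evidence that the other end of the molecule also counts in this assay: chloro in place of methoxy gives a 2.4-fold higher number from compound 2 to compound 3 (0.38 log units; beyond the scatter). The position, on an aromatic carbon ortho to a large group and meta to a carboxy group, is therefore not indifferent to its substituent, although the step is modest and compound 3 loses part of what the isobutyl ketone of compound 2 gained over the isopropyl ketone of compound 1. Nothing in the material shown gives a reason for this shift.

With only methoxy and chloro shown here, the compounds leave open how fluoro, methyl, ethoxy or hydroxy at the same carbon would compare, and so whether the step follows from losing methoxy or from introducing chloro. They also leave open whether the same exchange would give a step of similar size with the isopropyl ketone of compound 1, and how it would behave if the carboxylic acid gave way to an amide or a tetrazole.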